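This account rests on a few compounds, and the source may have more. Where it says the series, first, only, none or still open, it means among the compounds named here.

Measured so far in a functional assay on MCF7 cells (Homo sapiens) for antiproliferative activity, read by sulforhodamine B assay, with a stated time of 48 h; on this read-out higher numbers stand for weaker inhibition and lower numbers for stronger inhibition:

- compound 1 `COc1ccccc1OS(=O)(=O)c1ccc(N2CCN(C)C2=O)cc1` gives 26000 nM
- compound 2 `Cc1cccc(OS(=O)(=O)c2ccc(N3CCN(C)C3=O)cc2)c1` gives 5100 nM
- compound 3 `CCCN1CCN(c2ccc(S(=O)(=O)Oc3ccccc3OC)cc2)C1=O` gives 13000 nM

Compound 3 (13000 nM) cannot be told apart from compound 1, since the data show a 2.0-fold lower number from compound 1 to compound 3 (0.30 log units; within the scatter). Compound 2 (5100 nM) has a clearly lower number than either of them.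

Compound 4 `CCCN1CCN(c2ccc(S(=O)(=O)Oc3cccc(C)c3)cc2)C1=O` is compound 3 with a single change, (3-methylphenyl in place of 2-methoxyphenyl on an oxygen). This is 3-methylphenyl in place of 2-methoxyphenyl on an oxygen, the one bound to the sulfonyl sulfur.

The same swap has been measured once, on the core of compound 1, where it gave a 5.1-fold lower number from compound 1 to compound 2 (0.71 log units; beyond the scatter). That is a modest step, but one that stands clear of the scatter. The other measured step, a 2.0-fold lower number from compound 1 to compound 3 (0.30 log units; within the scatter), shows that the longer chain on its own moved the number by no more than the scatter, so it offers little reason to expect the swap to behave differently on compound 3. Still, one pair is thin evidence, and nothing yet shows that the swap carries over unchanged.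

Going by compound 2 and its 5100 nM, the expected result in this assay is a 5.0-fold lower number from compound 3 to compound 4 (0.70 log units; beyond the scatter), a modest move toward stronger inhibition.

Compound 4 is estimated at 2600 nM with 1000 nM to 6500 nM as the expected range.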

Compound 4, half-maximal inhibitory concentration: 86000 nM
For compound 4 the middle estimate is 33-fold (1.52 log units) below the measured one; measured number above the stated range.
By their numbers in this assay, from the lowest: compound 2; then compounds 3 and 1 (each within the scatter of the next); then compound 4.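

In this assay, the change from 2-methoxyphenyl to 3-methylphenyl on the oxygen bound to the sulfonyl sulfur has no fixed effect, since on the longer-chain core it gives a 6.6-fold higher number from compound 3 to compound 4 (0.82 log units; beyond the scatter), and its direction depends on the rest of the molecule: the same change on two cores in this assay, a 5.1-fold lower number (0.71 log units; beyond the scatter) from compound 1 to compound 2 and a 6.6-fold higher number (0.82 log units; beyond the scatter) from compound 3 to compound 4, 34-fold (1.53 log units) apart, beyond the scatter of two such steps. The longer chain on the amide-type nitrogen in the ring, which made no difference beyond the scatter with 2-methoxyphenyl in place, gives a 17-fold higher number from compound 2 to compound 4 (1.23 log units; beyond the scatter) with 3-methylphenyl in place: the same change on two cores in this assay, a 2.0-fold lower number (0.30 log units; within the scatter) from compound 1 to compound 3 and a 17-fold higher number (1.23 log units; beyond the scatter) from compound 2 to compound 4, 34-fold (1.53 log units) apart, beyond the scatter of two such steps. The two sites therefore do not act independently in this set, and the effect of either change can only be read with the other site in view.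

The four compounds form a single square of two aryl groups and two chains, so they cannot show whether the reversal belongs to 3-methylphenyl in particular or appears with other groups on that oxygen, or how it develops with chain length. A plain phenyl on the oxygen, or an ethyl or butyl chain on the nitrogen, would help to separate these possibilities.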